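Opening the ring on the amide arm of compound 3

The source may report more compounds than this note shows. Statements on the series, on what has been measured and on what is new or still open speak of the compounds shown alone.

Compound 3 `O=C(CN1CN(c2ccccc2)C2(CCN(C(=O)c3ccc(C4CCCCC4)cc3)CC2)C1=O)N1CCCCC1` carries a shared core bearing a cyclohexylphenyl amide and a piperidin-1-yl amide arm. In an assay on HEK293 cells for displacement of a labelled ligand from NPC1-like intracellular cholesterol transporter 1 (Homo sapiens) (on this read-out higher numbers stand for weaker inhibition and lower numbers for stronger inhibition), compound 3 gives 1100 nM. Compound 1 `O=C(CN1CN(c2ccccc2)C2(CCN(C(=O)c3ccc(C4CCCCC4)cc3)CC2)C1=O)N1CCC(CO)CC1` adds a hydroxymethyl group to that ring, and compound 1 gives 1100 nM; the two numbers are level (no change at the digits printed from compound 1 to compound 3 (within the scatter)). Compound 2 `COC(=O)CCCNC(=O)CN1CN(c2ccccc2)C2(CCN(C(=O)c3ccc(C4CCCCC4)cc3)CC2)C1=O` carries an open-chain amide arm instead, and compound 2 gives 2500 nM. Compound 3 and compound 1 thus share the lowest numbers of the three, while compound 2 sits higher (a 2.3-fold lower number from compound 2 to compound 3 (0.36 log units; beyond the scatter)).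

Compound 4 `CC(C)(C)OC(=O)NCNC(=O)CN1CN(c2ccccc2)C2(CCN(C(=O)c3ccc(C4CCCCC4)cc3)CC2)C1=O` differs from compound 3 by (((tert-butoxycarbonyl)amino)methyl)amino in place of piperidin-1-yl on a carbonyl carbon. Among the measured compounds shown here, the nearest precedent is the step of a 2.3-fold lower number from compound 2 to compound 3 (0.36 log units; beyond the scatter), where closing an open-chain amide into the piperidin-1-yl ring brought a modestly lower number; the step of a 2.3-fold higher number from compound 1 to compound 2 (0.36 log units; beyond the scatter) ran in the same sense. Compound 4 reverses that move, so a modestly higher number is expected, a 2.0-fold higher number from compound 3 to compound 4 (0.30 log units; within the scatter). The estimate for compound 4 is 2200 nM, with a range from 900 nM to 5000 nM.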

Compound 4, half-maximal inhibitory concentration: 1700 nM
The estimate for compound 4 lay 1.3-fold (0.11 log units) above the measured number; measured number inside the range.
By their numbers in this assay, from the lowest: compounds 1, 3, 4 and 2 (each within the scatter of the next, the first and the last beyond it).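

In this assay, putting the open-chain (((tert-butoxycarbonyl)amino)methyl)amino group in place of piperidin-1-yl on this carbonyl carbon gives a 1.5-fold higher number from compound 3 to compound 4 (0.19 log units; within the scatter) and the comparison with the hydroxymethyl ring reads a 1.5-fold higher number from compound 1 to compound 4 (0.19 log units; within the scatter) so compound 4 cannot be told apart from either ring amide. The other open-chain comparison gives a 1.5-fold lower number from compound 2 to compound 4 (0.17 log units; within the scatter) so compound 4 also cannot be told apart from compound 2, even though compound 2 stands beyond the scatter from both ring amides, and an open chain at this position therefore does not always separate from the rings. Nothing measured here gives a reason for these numbers.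

From the compounds shown here alone, it remains open whether a free amine or a carboxylic acid at the end of the open chain would give a number beyond the scatter from these four compounds. Going by these compounds, a longer chain carrying the tert-butoxycarbonyl group is equally open.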